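This account rests on a few compounds, and the source may have more. Where it says the series, first, only, none or still open, it means among the compounds named here.

Measured so far:
compound 1 `O=C(CSc1nc(Nc2ccccc2)c2ccccc2n1)Nc1cccc(Br)c1`, 9620 nM
compound 2 `CCc1cccc(NC(=O)CSc2nc(Nc3ccccc3)c3ccccc3n2)c1`, 15800 nM
compound 3 `C=CC(=O)Nc1cccc(NC(=O)CSc2nc(Nc3ccccc3C)c3ccccc3n2)c1`, 30200 nM

In a functional assay on MGC-803 cells (Homo sapiens) for inhibition, read by MTT assay, with a stated time of 72 h (on this read-out lower numbers stand for stronger inhibition and higher numbers for weaker inhibition), compound 3 gives the highest of the three numbers: against compound 2 the gap is within the scatter, against compound 1 it lies beyond it. Compound 4 `C=CC(=O)Nc1cccc(NC(=O)CSc2nc(Nc3cc(OC)c(OC)c(OC)c3)c3ccccc3n2)c1` differs from compound 3 at the amine-bearing side of the shared core: 3,4,5-trimethoxyphenyl in place of 2-methylphenyl on a nitrogen on an aromatic ring. Among the measured compounds shown here, no measured step touches this position. For the measured compounds named here, the only step available, a 1.6-fold higher number from compound 1 to compound 2 (0.22 log units; within the scatter), concerns the other aryl and is itself within the scatter, so it gives no direction for this change. For compound 4 the expectation is therefore no step beyond the scatter, a 1.2-fold lower number from compound 3 to compound 4 (0.08 log units; within the scatter), with wide uncertainty. Compound 4 is estimated at 25000 nM, range 8000 nM to 80000 nM.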

Compound 4, half-maximal inhibitory concentration: > 50000 nM
Compound 4: a limit, no number (the forecaster's own chance of this, stated with the estimate: 10%); middle value at least 2.0-fold (0.30 log units) away from the limit.
By their numbers in this assay, from the lowest: compounds 1, 2 and 3 (each within the scatter of the next, the first and the last beyond it). At a limit, above all of these: compound 4.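

In this assay, among the compounds shown here, this is the first step read at the amine-bearing side of the shared core, and 3,4,5-trimethoxyphenyl in place of 2-methylphenyl on a nitrogen on an aromatic ring gives an at least 1.6-fold higher number from compound 3 to compound 4 (0.21 log units; that floor lies within the scatter). No gain in inhibition appears with this change, but its true size stays undetermined. Compound 4 carries a limit, not a number: the limit of > 50000 nM in this assay, at which 1 of the 4 values shown sits.

From the compounds shown here alone, whether a single methoxy group or a dimethylamino group on this aryl would read inside the limit stays open. Also open, going by these compounds, is whether the step holds with bromo or ethyl on the other aryl.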